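Cytotoxicity at the Limit: Cyano Versus Carbamoyl Analogues

The source may report more compounds than this note shows. Statements on the series, on what has been measured and on what is new or still open speak of the compounds shown alone.

Three compounds share a core that carries a hydroxamic acid and a benzyl arm, and differ only in the group on that arm. Compound 1 is `N#Cc1cccc(Cn2ccc3cc(C(=O)NO)ncc32)c1`, compound 2 is `N#Cc1ccc(Cn2ccc3cc(C(=O)NO)ncc32)cc1`, and compound 3 is `NC(=O)c1cccc(Cn2ccc3cc(C(=O)NO)ncc32)c1`. In an ADME assay on CEM-SS cells (Homo sapiens) for cytotoxicity, read by XTT assay (on this read-out higher numbers stand for lower toxicity in this test and lower numbers for higher toxicity in this test), compound 1 gives > 10000 nM, which is a limit of the assay and not a number. Compound 2 gives > 10000 nM in this assay, again a limit. Compound 3 gives > 10000 nM in this assay, also a limit.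

Compound 1 and compound 3 differ by carbamoyl in place of cyano on an aromatic carbon. The resulting step, a step that the two limits leave unreadable from compound 1 to compound 3, cannot be read because of the limit of > 10000 nM in this assay, at which 3 of the 3 values shown sit. Compound 1 and compound 2 have the same atoms joined differently; the difference between the two cores is not broken down here.

The unmeasured compound 4 is `NC(=O)c1ccc(Cn2ccc3cc(C(=O)NO)ncc32)cc1`. It differs from compound 2 by carbamoyl in place of cyano on an aromatic carbon. This is the same kind of change as from compound 1 to compound 3, but the place differs: meta to a large group in the one case, para to a large group in the other. Since compound 2 sits at a limit, as do compound 1 and compound 3, the step that the limit leaves unreadable from compound 2 to compound 4 is expected to stay unreadable in this assay. Compound 4 is therefore estimated at 15000 nM in this assay, most likely reported as a limit again.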

Compound 4, half-maximal cytotoxic concentration: > 10000 nM
Compound 4 was reported as a limit; the forecaster's own chance of this, stated with the estimate: 85%; the middle value is on the limit's open side.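

The change from cyano to carbamoyl between compound 2 and compound 4 gives no step that can be read, because each compound's result is a limit of the assay and not a number: the limit of > 10000 nM in this assay, at which 4 of the 4 values shown sit.

The compounds shown leave open how far apart their true values lie in this assay, and whether swapping cyano for carbamoyl changes toxicity in this test at all.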